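The source may hold more compounds than are shown below. What is called first, only, known or untested is meant among the compounds shown, and "the series" means these compounds.

Compound 1 `CCOC(=O)c1cnc(-c2cccs2)nc1NN1C(=O)C=C(C)C1=O` is the starting point of this comparison. For the measured compounds named here, in a functional assay on Jurkat cells for inhibition of nuclear factor NF-kappa-B complex (Homo sapiens) (on this read-out lower numbers stand for stronger inhibition and higher numbers for weaker inhibition), compound 1 gives 20 nM, the lowest of the three numbers measured so far. Compound 2 `CCOC(=O)c1cnc(-c2ccc(Cl)s2)nc1NN1C(=O)C=C(C)C1=O` gives 300 nM in this assay, and compound 3 `CCOC(=O)c1cnc(-c2cc(Cl)cc(Cl)c2)nc1NN1C(=O)C=C(C)C1=O` gives 300 nM. Both of the measured steps away from compound 1 point the same way: a 15-fold higher number from compound 1 to compound 2 (1.18 log units; beyond the scatter) and a 15-fold higher number from compound 1 to compound 3 (1.18 log units; beyond the scatter), each a large loss, while no change at the digits printed from compound 2 to compound 3 (within the scatter). Compound 4 `CC1=CC(=O)N(Nc2nc(-c3cccs3)ncc2-c2nnc(C)o2)C1=O` differs from compound 1 in another place entirely: 5-methyl-1,3,4-oxadiazol-2-yl in place of ethoxycarbonyl on an aromatic carbon. Going by the values given here, no measured step touches the ethoxycarbonyl group, so none of the steps above bears directly on this change; they only show that compound 1 is easily weakened by changes elsewhere. The step is therefore expected to be small to moderate, most likely toward a higher number, though a change within the scatter cannot be excluded: a 3.0-fold higher number from compound 1 to compound 4 (0.48 log units; beyond the scatter) is the expected step. Compound 4 is estimated at 60 nM in this assay, with a plausible range from 12 nM to 400 nM.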

Compound 4, half-maximal inhibitory concentration: 300 nM
Estimate against measurement, compound 4: 5.0-fold (0.70 log units) below; the range from low to high includes it.
By their numbers in this assay, from the lowest: compound 1; then compounds 2, 3 and 4 (each within the scatter of the next).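

In this assay the change at this position gives a 15-fold higher number from compound 1 to compound 4 (1.18 log units; beyond the scatter), so the carbon carrying the ethoxycarbonyl group is not a place where compound 1 tolerates this replacement. The earlier steps shown here concerned only the thiophen-2-yl group, and this step shows that a change at the other end of the shared core can cost as much as a 15-fold higher number from compound 1 to compound 2 (1.18 log units; beyond the scatter) does there. The data at hand give no measured property that would explain this loss. On these data alone, it remains open whether the loss belongs to the 5-methyl-1,3,4-oxadiazol-2-yl ring in particular or follows from losing the ethoxycarbonyl group in general. A methyl ester, a primary amide or a carboxylic acid on the same carbon, or the same ring without its methyl group, would be needed to separate these two readings.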